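The source may hold more compounds than are shown below. What is called first, only, known or untested is meant among the compounds shown, and "the series" means these compounds.

Of the compounds shown here, two sharing one core have been tested so far. In a functional assay on ECa-109 cells for inhibition, with ECa-109 cell line (Homo sapiens) as the target, read by MTT assay, with a stated time of 48 h (a higher number here means a weaker inhibitor, a lower number a stronger inhibitor), compound 1 `COc1cc(Nc2nnc(Cl)c(Nc3cc(OC)c(OC)c(OC)c3)n2)cc(OC)c1OC` gives > 50000 nM, which is a limit of the assay and not a number. For the measured compounds named here, compound 2 `CCOC(=O)c1ccc(Nc2nnc(Cl)c(Nc3cc(OC)c(OC)c(OC)c3)n2)cc1` gives 46600 nM, the only actual number available, so it has no measured neighbour against which a step could be sized. The next compound keeps the core and the trimethoxy-bearing side of compound 2 and changes one group. Compound 3 `COc1cc(Nc2nc(Nc3ccc(Br)cc3)nnc2Cl)cc(OC)c1OC` carries bromo in place of ethoxycarbonyl on an aromatic carbon, para to a large group (bromo in place of ethoxycarbonyl on an aromatic carbon). Going by the values given here, with no measured step to draw on, the expected change in this assay, given as a 1.6-fold lower number from compound 2 to compound 3 (0.19 log units; within the scatter), is estimated to stay within the usual scatter, leaning slightly towards a stronger inhibitor. For compound 3 the expected value is 30000 nM, with an estimated range of 12000 nM to 50000 nM.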

Compound 3, half-maximal inhibitory concentration: 41600 nM
Estimate against measurement, compound 3: 1.4-fold (0.14 log units) below; low and high end bracket the measured number.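

For the compounds shown here, at this position, on an aromatic carbon para to a large group, this assay does not tell ethoxycarbonyl and bromo apart, giving the first measured step: a 1.1-fold lower number from compound 2 to compound 3 (0.05 log units; within the scatter). The exchange removes the hydrogen-bond acceptors of ethoxycarbonyl and brings in a bromo that has none, and the step still stays within the scatter, so this read-out gives no sign that those acceptors matter here. Compound 3 remains with compound 2 in the weak range, close to the top of what the assay reports: the limit of > 50000 nM in this assay, at which 1 of the 3 values shown sits.

The compounds shown leave open whether an amine or a carboxylic acid at this position would shift the number beyond the scatter. They also leave open whether a change on the trimethoxy-bearing side would matter more than this one.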